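Swapping a chloro-bearing phenoxy group for a trifluoromethyl one

The compounds below may be only part of what the source reports. "The series", "measured", "known", "first", "only" and "open" are said of these compounds alone.

Measured compounds:
- Compound 1, `Cc1ccc(Oc2cccc(CN3CCC(n4cc(C)c(=O)[nH]c4=O)CC3)c2)cc1`: in an ADME assay on MRC5 cells (Homo sapiens) for cytotoxicity, read by fluorescence and resazurin assay, with a stated time of 3 days (a higher number here means a weaker inhibitor, a lower number a stronger inhibitor), compound 1 gives > 64000 nM, which is a limit of the assay and not a number.
- Compound 2, `Cc1cccc(Oc2cccc(CN3CCC(n4cc(C)c(=O)[nH]c4=O)CC3)c2)c1`: compound 2 gives > 64000 nM, again a limit of the assay.
- Compound 3, `Cc1cn(C2CCN(Cc3cccc(Oc4ccc(Cl)cc4)c3)CC2)c(=O)[nH]c1=O`: compound 3 gives 25100 nM.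

Compound 3 is the only compound with a measured number; the other two values sit at a limit, as shown by the limit of > 64000 nM in this assay, at which 2 of the 3 values shown sit. Compound 4, `Cc1cn(C2CCN(Cc3cccc(Oc4cccc(C(F)(F)F)c4)c3)CC2)c(=O)[nH]c1=O`, has not yet been measured. It differs from compound 3 only in one place: 3-(trifluoromethyl)phenyl in place of 4-chlorophenyl on an oxygen on an aromatic ring.

Among the measured compounds shown here, no measured step changes exactly this group, so the evidence is indirect. The two steps that reach compound 3 show what a change on this phenyl can do: an at least 2.5-fold lower number from compound 1 to compound 3 (0.40 log units; beyond the scatter) and an at least 2.5-fold lower number from compound 2 to compound 3 (0.40 log units; beyond the scatter). Going by these compounds, both point to a number at least as low as the limits allow reading, but neither involves a trifluoromethyl group, so the direction of the present step remains open.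

The expectation for compound 4 is therefore a number close to that of compound 3, with a wide range: compound 4 is estimated at 22000 nM, between 8000 nM and 64000 nM. This estimate means a step of a 1.1-fold lower number from compound 3 to compound 4 (0.06 log units; within the scatter), and a value at the limit cannot be excluded.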

Compound 4, half-maximal inhibitory concentration: 12400 nM
Estimate against measurement, compound 4: 1.8-fold (0.25 log units) above, within the range that was stated.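

In this assay, replacing 4-chlorophenyl with 3-(trifluoromethyl)phenyl gives a 2.0-fold lower number from compound 3 to compound 4 (0.31 log units; beyond the scatter), so this change on the oxygen takes the number further from the limit, and compound 4 is the strongest inhibitor of the four compounds shown. The distance from the two methyl-bearing compounds also grows, with an at least 5.1-fold lower number from compound 2 to compound 4 (0.71 log units; beyond the scatter) and an at least 5.1-fold lower number from compound 1 to compound 4 (0.71 log units; beyond the scatter). Both of these sizes are only minimum sizes, because each starts from a limit of the assay and not from a number: the limit of > 64000 nM in this assay, at which 2 of the 4 values shown sit.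

4-chlorophenyl and 3-(trifluoromethyl)phenyl differ in both the substituent and its numbered place on the ring, and the compounds shown do not separate these two changes. Also open, going by these compounds, is how the number in this assay would respond to a different kind of group on this ring, such as an amine or a carboxylic acid, since the four compounds carry only methyl, chloro and trifluoromethyl there.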